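This account rests on a few compounds, and the source may have more. Where it says the series, first, only, none or still open, it means among the compounds named here.

Compound 1 `COc1cc(C(=O)c2sc(-c3ccc(Cl)c(Cl)c3)cc2N)cc(OC)c1OC` carries a 3,4-dichlorophenyl group on its five-membered aromatic ring with one sulfur. Among the measured compounds shown here, in a functional assay on FM3A cells (Mus musculus) for antiproliferative activity (on this read-out higher numbers stand for weaker inhibition and lower numbers for stronger inhibition), compound 1 gives 400 nM, the second highest of the three numbers measured so far. Compound 2 `COc1cc(C(=O)c2sc(-c3ccc(C(F)(F)F)cc3)cc2N)cc(OC)c1OC` gives 540 nM in this assay, and compound 3 `COc1cc(C(=O)c2sc(-c3ccncc3)cc2N)cc(OC)c1OC` gives 150 nM. The step of a 1.4-fold higher number from compound 1 to compound 2 (0.13 log units; within the scatter) stays within the scatter, whereas a 2.7-fold lower number from compound 1 to compound 3 (0.43 log units; beyond the scatter) and a 3.6-fold lower number from compound 2 to compound 3 (0.56 log units; beyond the scatter) are modest but beyond it.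

Compound 4 `COc1cc(C(=O)c2sc(-c3ccc(Br)cc3)cc2N)cc(OC)c1OC` has not yet been measured. It differs from compound 1 in one place: 4-bromophenyl in place of 3,4-dichlorophenyl on an aromatic carbon. The step from compound 1 to compound 2, which likewise exchanges one substituted phenyl for another, is the one that bears most directly on this change, and it was within the scatter; the larger steps to compound 3 involve pyridin-4-yl and so say less here. Compound 4 is therefore expected to show no step beyond the scatter, a 1.1-fold higher number from compound 1 to compound 4 (0.05 log units; within the scatter). The estimate for compound 4 is 450 nM, with an expected range from 200 nM to 1000 nM.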

Compound 4, half-maximal inhibitory concentration: 150 nM
Beside the measured number, compound 4's estimate is 3.0-fold (0.48 log units) above it; measured number outside the range, below it.
By their numbers in this assay, from the lowest: compounds 3 and 4 (each within the scatter of the next); then compounds 1 and 2 (each within the scatter of the next).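

In this assay, the choice of substituted phenyl on the aromatic carbon next to the ring sulfur can matter, which compounds 1 and 2 alone had not shown: with a 2.7-fold lower number from compound 1 to compound 4 (0.43 log units; beyond the scatter) and a 3.6-fold lower number from compound 2 to compound 4 (0.56 log units; beyond the scatter), both steps lie beyond the scatter. The lower numbers are also not confined to pyridin-4-yl, as the 4-bromophenyl group gives no change at the digits printed from compound 3 to compound 4 (within the scatter) and so stands level with it. No available evidence accounts for how the 4-bromophenyl group differs from the other two phenyl groups.

The compounds shown leave open whether 4-chlorophenyl would read with compound 4 or with compound 1, which would separate the loss of one chlorine from the exchange of chlorine for bromine. On these data alone, how an amine or a carboxylic acid on this phenyl ring would read also remains open.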